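Swapping an ether for a ketone on a shared core

A few compounds are considered here, and "the series" means these few. Any claim that something is new, unique, unknown or untested is made for them only; others in the source may bear on it.

Measured so far:
compound 1, `C=CCc1cccc(CC=C)c1OC(C)C1=NCCN1`: 0.65
compound 2, `CC(Oc1ccccc1OC1CC1)C1=NCCN1`: 0.6

Both compounds were tested in an assay on CHO cells with Alpha-2B adrenergic receptor (Homo sapiens) as the target; a higher number here means a larger maximal response, a lower number a smaller maximal response. There compound 1 gives 0.65, a partial maximal response. Compound 2 gives 0.6 in this assay. Among the two numbers compound 2 is the one with the smaller figure on paper, but the gap to compound 1 lies within the usual scatter of repeated measurements, so the two compounds cannot be told apart on this read-out.

The next compound, compound 3, `CC(=O)c1ccccc1OC(C)C1=NCCN1`, is not yet measured. It differs from compound 2 in one place: acetyl in place of cyclopropyloxy on an aromatic carbon. Among the measured compounds shown here, no measured pair here shows what such a change does to the maximal response, so nothing more than the two recorded numbers can guide an expectation.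

For the measured compounds named here, with only two compounds sitting close together, the expected step of no change at the digits printed from compound 2 to compound 3 (within the scatter) is none beyond the scatter. Compound 3 is expected to give 0.6 in this assay, within a range from 0.4 to 0.8.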

Compound 3, intrinsic activity: the largest response reached, as a fraction of the reference agonist's: 0.6
Compound 3: the middle estimate sits on the measured number at the digits printed; low and high end bracket the measured number.
By their numbers in this assay, from the lowest: compounds 2, 3 and 1 (each within the scatter of the next).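

In this assay, putting acetyl in place of cyclopropyloxy on this aromatic carbon, which is ortho to a group of 8 heavy atoms, gives no change at the digits printed from compound 2 to compound 3 (within the scatter). Among the compounds shown here, this is the first direct reading of a single change at this position, since compound 1 and compound 2 differ in more than one place and could not show what one swap does. The swap removes a three-membered ring and brings in a double bond outside aromatic rings, while the count of one hydrogen-bond acceptor stays the same, yet the two numbers cannot be told apart, and nothing measured here offers an explanation for this outcome.

Going by these compounds, whether an amine, a carboxylic acid or a longer chain on this aromatic carbon would move the maximal response beyond the scatter remains open, so the tolerance seen here rests on a single pair. That pair also leaves open whether the same swap would behave alike on another core, or on a read-out other than the maximal response.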